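Swapping the Ring at the End of the Chain

The source may hold more compounds than are shown below. What is called first, only, known or untested is meant among the compounds shown, and "the series" means these compounds.

Compound 2 `COc1cc2c(Oc3ccc(NC(=O)c4nnn(-c5ccccc5C(F)(F)F)c4C)cc3F)ccnc2cc1OCCCN1CCCCC1` is one of two compounds tested in a functional assay on A549 cells (Homo sapiens) for cytotoxicity, read by MTT assay, with a stated time of 72 h; a higher number here means a weaker inhibitor, a lower number a stronger inhibitor. In this assay compound 2 gives 170 nM, while compound 1 `COc1cc2c(Oc3ccc(NC(=O)c4nnn(-c5ccccc5C(F)(F)F)c4C)cc3F)ccnc2cc1OCCCN1CCCC1` gives 160 nM; the step of a 1.1-fold higher number from compound 1 to compound 2 (0.03 log units; within the scatter) lies within the scatter, so the two stand together rather than apart. Compound 3 `COc1cc2c(Oc3ccc(NC(=O)c4nnn(-c5ccccc5C(F)(F)F)c4C)cc3F)ccnc2cc1OCCCN1CCN(C)CC1` has not yet been measured. It differs from compound 2 in one place: 4-methylpiperazin-1-yl in place of piperidin-1-yl on a saturated chain carbon, three bonds along the chain from an oxygen on an aromatic ring. For the measured compounds named here, the only measured step that bears on this position is a 1.1-fold higher number from compound 1 to compound 2 (0.03 log units; within the scatter), in which one saturated ring gave way to another at the same end of the chain without any effect beyond the scatter. Going by the values given here, on that basis the step of a 1.1-fold higher number from compound 2 to compound 3 (0.05 log units; within the scatter) is expected to stay within the scatter as well, although no measured pair tests the 4-methylpiperazin-1-yl group itself. Compound 3 is therefore expected to give about 190 nM in this assay, with a range from 90 nM to 400 nM.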

Compound 3, half-maximal inhibitory concentration: 200 nM
Compound 3: the middle estimate sits 1.1-fold (0.02 log units) below what was measured, within the range that was stated.
By their numbers in this assay, from the lowest: compounds 1, 2 and 3 (each within the scatter of the next).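

In this assay the entry of 4-methylpiperazin-1-yl gives a 1.2-fold higher number from compound 2 to compound 3 (0.07 log units; within the scatter) when it replaces piperidin-1-yl and a 1.3-fold higher number from compound 1 to compound 3 (0.10 log units; within the scatter) when it replaces pyrrolidin-1-yl. For the compounds shown here, the earlier pair showed only that one ring with a single hetero atom could take the place of another at the end of the chain. This result adds that a ring with a second nitrogen, carrying a methyl group, also leaves the number within the scatter of both earlier compounds, so all three stand together.

From the compounds shown here alone, whether a morpholin-4-yl ring, an open-chain dimethylamino group or a longer chain would stay within the scatter as well remains open. Nothing measured here offers a reason why these three ring changes leave the compounds unseparated.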